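The source may report more compounds than this note shows. Statements on the series, on what has been measured and on what is new or still open speak of the compounds shown alone.

Measured so far:
compound 1 `Cc1cccc(NC(=O)Nc2nnc(Sc3ncnc4scc(-c5ccncc5)c34)s2)c1` — 20700 nM
compound 2 `O=C(Nc1cccc(Cl)c1)Nc1nnc(Sc2ncnc3scc(-c4ccncc4)c23)s1` — 22900 nM
compound 3 `Cc1ccc(NC(=O)Nc2nnc(Sc3ncnc4scc(-c5ccncc5)c34)s2)cc1Cl` — 16000 nM

In a functional assay on HepG2 cells (Homo sapiens) for antiproliferative activity, read by MTT assay, with a stated time of 48 h (a lower number here means a stronger inhibitor, a higher number a weaker inhibitor), compound 3 holds the lowest of the three numbers, yet every step to it stays within the scatter: a 1.3-fold lower number from compound 1 to compound 3 (0.11 log units; within the scatter) and a 1.4-fold lower number from compound 2 to compound 3 (0.16 log units; within the scatter). The three values are, in effect, one level.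

Compound 4 `O=C(Nc1ccc(F)cc1)Nc1nnc(Sc2ncnc3scc(-c4ccncc4)c23)s1` differs from compound 3 by 4-fluorophenyl in place of 3-chloro-4-methylphenyl on an amide-type nitrogen. Among the compounds with values here, the steps that bear on it are the swaps on the same aryl ring, a 1.1-fold higher number from compound 1 to compound 2 (0.04 log units; within the scatter) and a 1.4-fold lower number from compound 2 to compound 3 (0.16 log units; within the scatter), both within the scatter. Within the data shown here, no measured step brings in fluorine or strips both ring substituents at once, so no step beyond the scatter is expected in this assay; the anticipated step is a 1.4-fold higher number from compound 3 to compound 4 (0.14 log units; within the scatter). For compound 4 the estimate is 22000 nM, with a range from 9000 nM to 55000 nM.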

Compound 4, half-maximal inhibitory concentration: 31700 nM
Compound 4: the middle estimate sits 1.4-fold (0.16 log units) below what was measured; measured number inside the range.
By their numbers in this assay, from the lowest: compounds 3, 1, 2 and 4 (each within the scatter of the next).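

Even with 4-fluorophenyl on the amide-type nitrogen, the one fluorine-bearing ring among these compounds, every step in this assay remains within the scatter (a 2.0-fold higher number from compound 3 to compound 4 (0.30 log units; within the scatter)) and (a 1.4-fold higher number from compound 2 to compound 4 (0.14 log units; within the scatter)) and (a 1.5-fold higher number from compound 1 to compound 4 (0.19 log units; within the scatter)). Across the four compounds, methyl, chloro and fluoro ring substituents therefore give one level at this position, with no exception among them. Nothing available bears on a cause for this flatness. Still open, as far as these compounds go, is whether an amine or a carboxylic acid on this ring, or a longer alkyl chain in place of the ring, would give a step beyond the scatter.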